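The source may report more compounds than this note shows. Statements on the series, on what has been measured and on what is new or still open speak of the compounds shown alone.

Measured compounds:
compound 1, `CN(C(=O)C(c1ccccc1)c1ccccc1)c1cc(C(F)(F)F)cc(C(F)(F)F)c1`, gives 301 nM
compound 2, `COc1cc(CNC(=O)CC(c2ccccc2)c2ccccc2)cc(OC)c1`, gives 2240 nM

Of the compounds shown here, two have been measured in an assay on CHO cells for displacement of a labelled ligand from Substance-P receptor (Homo sapiens); a higher number here means a weaker inhibitor, a lower number a stronger inhibitor. Within the data shown here, of the two numbers, the one from compound 2 is the highest, and compound 1 sits a good way below it, beyond the usual scatter. Compound 1 and compound 2 differ in more than one place, so the gap between them cannot be tied to any single change; it only shows that compound 2 is the weaker of the pair.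

The step under consideration leads from compound 2 to compound 3, `COc1cc(CN(C)C(=O)CC(c2ccccc2)c2ccccc2)cc(OC)c1`. The change is small: methyl in place of hydrogen on an amide-type nitrogen. Among the measured compounds shown here, no pair of measured compounds differs in this one place alone, so there is no measured step of this kind to lean on. On the structural change alone, a modest shift is expected, more likely towards a lower number than a higher one, though a step within the scatter would not be surprising. The step from compound 2 to compound 3 is thus estimated at a 2.5-fold lower number from compound 2 to compound 3 (0.40 log units; beyond the scatter). For compound 3 the expected value in this assay is 900 nM, in a range from 250 nM to 3500 nM.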

Compound 3, half-maximal inhibitory concentration: 226 nM
For compound 3 the middle estimate is 4.0-fold (0.60 log units) above the measured one, and the stated range ends above it.
By their numbers in this assay, from the lowest: compounds 3 and 1 (each within the scatter of the next); then compound 2.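

In this assay, among these compounds, methyl in place of hydrogen on an amide-type nitrogen gives a 9.9-fold lower number from compound 2 to compound 3 (1.00 log units; beyond the scatter), and this is the first effect that can be tied to a single change. It shows that this nitrogen is a sensitive position in the shared core: the amide hydrogen can be replaced, and adding one carbon there gives a stronger inhibitor, with a shift well beyond the scatter. No information is available on why this single replacement has such an effect.

The compounds shown leave open whether the gain is specific to methyl or extends to a longer chain such as ethyl or propyl on the same nitrogen, and whether a larger group such as benzyl, or a chain ending in an amine or a carboxylic acid, would be accepted there. Among the compounds shown here, they also leave open whether the same replacement would shift the number similarly on other cores, since this single pair is the only direct comparison available for this change.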